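Swapping 1-Carboxycyclopropyl for 1-Carboxy-1-methylethyl

The source may report more compounds than this note shows. Statements on the series, on what has been measured and on what is new or still open speak of the compounds shown alone.

In an ADME assay on microsomes from liver (Mus musculus) for metabolic stability (a higher number here means faster removal of the compound, a lower number slower removal), compound 3 `O=C(O)C1(c2nn(Cc3cn4cc(OCC5CC5)c(Cl)cc4n3)c3ccccc3c2=O)CC1` gives < 53.4 mL/min/kg as a limit and not a number. Compound 1 `O=C(O)Cn1nc(Cc2cn3cc(OCC4CC4)c(Cl)cc3n2)c2ccccc2c1=O` gives < 58.4 mL/min/kg as a limit too. Compound 2 `O=C(O)Cc1nn(Cc2cn3cc(OCC4CC4)c(Cl)cc3n2)c2ccccc2c1=O` gives < 51.7 mL/min/kg as a limit as well. None of the three therefore has an exact reading. Compound 4 `CC(C)(C(=O)O)c1nn(Cc2cn3cc(OCC4CC4)c(Cl)cc3n2)c2ccccc2c1=O` carries 1-carboxy-1-methylethyl in place of 1-carboxycyclopropyl on an aromatic carbon. For the measured compounds named here, the one measured step involving this group is a step that the two limits leave unreadable from compound 2 to compound 3 and it gives no size to carry over. Hence a step that the limit leaves unreadable from compound 3 to compound 4 is the expected step, with nothing beyond the usual scatter. For compound 4 the estimated clearance in this assay is 45 mL/min/kg within a range from 25 mL/min/kg to 60 mL/min/kg and another limit is quite possible.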

Compound 4, clearance: < 63.4 mL/min/kg
Compound 4 ended at the assay's limit; the forecaster's own chance of this, stated with the estimate: 75%; the middle value is on the limit's open side.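

Compound 4 gives < 63.4 mL/min/kg, a limit and not a number. For the compounds shown here, compound 2 and compound 3 also carry only limits, so no step to compound 4 can be read. Going by these compounds, whether 1-carboxy-1-methylethyl and 1-carboxycyclopropyl differ in clearance stays open.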